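A (piperidin-1-yl)methyl group in place of hydroxy

A few compounds are considered here, and "the series" means these few. Any claim that something is new, unique, unknown or untested is made for them only; others in the source may bear on it.

Compound 1 `CN1CCN(CCn2c(N)c(-c3nc4ccccc4[nH]3)c3nc(C#N)c(C#N)nc32)CC1`: > 50000 nM
Compound 2 `N#Cc1nc2c(-c3nc4ccccc4[nH]3)c(N)n(CCO)c2nc1C#N`: 5520 nM

In a functional assay on Raji cells (Homo sapiens) for antiproliferative activity, read by MTT assay, with a stated time of 48 h (a higher number here means a weaker inhibitor, a lower number a stronger inhibitor), compound 1 gives > 50000 nM, which is a limit and not a number. Within the data shown here, compound 2 gives 5520 nM, the only true number so far. Compound 3 `N#Cc1nc2c(-c3nc4ccccc4[nH]3)c(N)n(CCCN3CCCCC3)c2nc1C#N` differs from compound 2 by (piperidin-1-yl)methyl in place of hydroxy on a saturated chain carbon, two bonds along the chain from an aromatic nitrogen. Among the measured compounds shown here, the one measured step that bears on this is an at least 9.0-fold lower number from compound 1 to compound 2 (0.95 log units; beyond the scatter), beyond the scatter, where hydroxy stands in place of 4-methylpiperazin-1-yl. With a ring-bearing group replacing hydroxy again, a higher number is expected in this assay, though perhaps a smaller rise. The expected change is a 3.3-fold higher number from compound 2 to compound 3 (0.51 log units; beyond the scatter). Compound 3 is estimated at 18000 nM, within 4500 nM to 70000 nM.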

Compound 3, half-maximal inhibitory concentration: 3380 nM
Beside the measured number, compound 3's estimate is 5.3-fold (0.73 log units) above it; the whole stated range lies above it.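

In this assay, a ring at the end of the chain does not by itself raise the number: the step reads a 1.6-fold lower number from compound 2 to compound 3 (0.21 log units; within the scatter), so hydroxy and (piperidin-1-yl)methyl cannot be told apart at this position. Replacing 4-methylpiperazin-1-yl with the same group gives an at least 14-fold lower number from compound 1 to compound 3 (1.17 log units; beyond the scatter), so the weak result belongs to compound 1 and not to every ring-bearing chain. Compound 1 stands at a limit of the assay, so both of its steps are bounds: the limit of > 50000 nM in this assay, at which 1 of the 3 values shown sits.

On these data alone, it remains open whether a morpholin-4-yl group, a carboxylic acid or a shorter chain at this place would read like compound 2 and compound 3 or like compound 1.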